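Swapping methoxy for trifluoromethyl on an ester and a carbamate

The compounds below may be only part of what the source reports. "The series", "measured", "known", "first", "only" and "open" are said of these compounds alone.

Measured compounds:
- compound 1, `COc1ccc(C(=O)OC(CCN(C)C)c2ccc(Cl)cc2)cc1`, in an assay on NIH3T3 cells with Urotensin-2 receptor (Homo sapiens) as the target (a lower number here means a smaller maximal response, a higher number a larger maximal response), gives 84%
- compound 2, `CN(C)CCC(OC(=O)c1ccc(C(F)(F)F)cc1)c1ccc(Cl)cc1`, in this assay gives 47%
- compound 3, `COc1ccc(NC(=O)OC(CCN(C)C)c2ccc(Cl)cc2)cc1`, in this assay gives 170%

Compound 3 stands highest of the three, and its distance to compound 1 and to compound 2 lies beyond the scatter in both cases. The difference between the cores of compound 1 and compound 3 is not broken down here.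

Within the ester pair, the change from compound 1 to compound 2 is trifluoromethyl in place of methoxy on an aromatic carbon. That single change made a step of a number 37 percentage points lower from compound 1 to compound 2 (beyond the scatter), a clear loss of maximal response.

Compound 4, `CN(C)CCC(OC(=O)Nc1ccc(C(F)(F)F)cc1)c1ccc(Cl)cc1`, is not yet measured. It relates to compound 3 exactly as compound 2 relates to compound 1: the change is trifluoromethyl in place of methoxy on an aromatic carbon, the same change as before, made on the carbamate core instead of the ester core.

Among the measured compounds shown here, only one example of this change has been measured, so the expectation for compound 4 rests on the step from compound 1 to compound 2 alone, together with the starting point set by compound 3 at 170%. On that basis a drop of similar size is expected, a step of roughly a number 40 percentage points lower from compound 3 to compound 4 (beyond the scatter). Since the core differs, the carbamate may not respond in the same way, so the range is kept wide. For compound 4 in this assay an efficacy of about 130% is estimated, most likely between 90% and 170%.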

Compound 4, largest response reached (reported as efficacy), in percent of the reference or control that the assay uses: 94%
Compound 4: the middle estimate sits 36 percentage points above what was measured, within the range that was stated.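

In this assay, trifluoromethyl in place of methoxy on the core of compound 3 gave a step of a number 76 percentage points lower from compound 3 to compound 4 (beyond the scatter), so the maximal response fell on this core as it had on the core of compound 1. The direction of the change therefore carried over from one core to the other, but its size did not: the same change on two cores in this assay, a number 37 percentage points lower (beyond the scatter) from compound 1 to compound 2 and a number 76 percentage points lower (beyond the scatter) from compound 3 to compound 4, 39 percentage points apart, beyond the scatter of two such steps. Among the compounds shown here, this shows that the loss seen on one core was a fair guide to the direction on the other but a poor guide to the exact size; with only two pairs, it does not show why the steps differ or how the same change would behave on a third core.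

The compounds shown have only methoxy or trifluoromethyl at this place on the aromatic ring, so they leave open how a smaller group such as fluorine, or a group such as nitrile, would shift the maximal response on either core. They also leave open whether the same swap would still lower the response if a cyclic amine such as piperidine took the place of the dimethylamino group.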